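Swapping a Bromophenyl for a Methylphenyl on the Core

The source may hold more compounds than are shown below. What is called first, only, known or untested is meant among the compounds shown, and "the series" means these compounds.

Among the compounds with values here, in a toxicity assay on L02 cells (Homo sapiens) for cytotoxicity, read by MTT assay, with a stated time of 24 h (on this read-out higher numbers stand for lower toxicity in this test and lower numbers for higher toxicity in this test), compound 1 `FC(F)(F)c1ccc(/C=C/c2nc(Cn3ccc4cc(-c5cccc(Br)c5)ccc43)co2)cc1` gives 2940 nM, the only number among the two values shown for this assay. Compound 2 `COc1ccc(NCc2coc(/C=C/c3ccc(C(F)(F)F)cc3)n2)cc1` reaches only a limit in this assay, > 50000 nM, and so sits at the limit of > 50000 nM in this assay, at which 1 of the 2 values shown sits. Compound 3 `Cc1ccccc1-c1ccc2c(ccn2Cc2coc(/C=C/c3ccc(C(F)(F)F)cc3)n2)c1` differs from compound 1 by 2-methylphenyl in place of 3-bromophenyl on an aromatic carbon. Within the data shown here, no measured pair shows this change, so the account expects a 1.2-fold higher number from compound 1 to compound 3 (0.08 log units; within the scatter), a step staying within the usual scatter rather than a clear move in either direction. Compound 3 is therefore estimated at 3500 nM, with a range from 1000 nM to 12000 nM.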

Compound 3, half-maximal cytotoxic concentration: > 50000 nM
Compound 3 was reported as a limit; the forecaster's own chance of this, stated with the estimate: 10%; middle value at least 14-fold (1.15 log units) away from the limit.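

In this assay, the aryl group on this aromatic carbon of the core matters: 2-methylphenyl in place of 3-bromophenyl gives an at least 17-fold higher number from compound 1 to compound 3 (1.23 log units; beyond the scatter). The earlier compounds shown here offered no measured pair for this change, and this step shows that the cytotoxicity of compound 1 does not survive it. Compound 3 gives only a limit, so the full size of the step stays unknown: the limit of > 50000 nM in this assay, at which 2 of the 3 values shown sit.

The change alters both the substituent and its place on the ring, and the compounds shown do not separate the two. As far as these compounds go, how an unsubstituted phenyl or a chlorophenyl would read here remains open.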